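The source may hold more compounds than are shown below. What is called first, only, known or untested is meant among the compounds shown, and "the series" means these compounds.

The measured compounds:
Compound 1, `Cc1ccccc1-n1cc(-c2ccc(NS(=O)(=O)c3c[nH]c(=O)[nH]c3=O)cc2)nn1`, gave 13600 nM in a functional assay on SGC-7901 cells (Homo sapiens) for antiproliferative activity, read by MTT assay, with a stated time of 24 h; on this read-out lower numbers stand for stronger inhibition and higher numbers for weaker inhibition.
Compound 2, `Cc1cccc(-n2cc(-c3ccc(NS(=O)(=O)c4c[nH]c(=O)[nH]c4=O)cc3)nn2)c1`, gave 17500 nM in this assay.
Compound 3, `O=c1[nH]cc(S(=O)(=O)Nc2ccc(-c3cn(-c4ccc(F)cc4)nn3)cc2)c(=O)[nH]1`, reached only a limit, > 20000 nM, in this assay.

Among the three, compound 3 stands at the edge of what this assay reports: its value is a limit of the measurement and not a number (the limit of > 20000 nM in this assay, at which 1 of the 3 values shown sits). Compound 4, `O=c1[nH]cc(S(=O)(=O)Nc2ccc(-c3cn(-c4ccc(Cl)cc4)nn3)cc2)c(=O)[nH]1`, differs from compound 3 by chloro in place of fluoro on an aromatic carbon. For the measured compounds named here, no measured step alters that substituent; the steps that touch the same ring are the ones onto the 4-fluorophenyl, an at least 1.4-fold higher number from compound 1 to compound 3 (0.16 log units; that floor lies within the scatter) and an at least 1.1-fold higher number from compound 2 to compound 3 (0.05 log units; that floor lies within the scatter), both within the scatter, as is a 1.3-fold higher number from compound 1 to compound 2 (0.11 log units; within the scatter). Every measured compound therefore sits near the limit, and no step beyond the scatter is expected in this assay for this change. Compound 4 is estimated at 20000 nM, with a range of 9000 nM to 45000 nM, and the expected step is a number no higher from compound 3 to compound 4 (the limit leaves the size open); a limit rather than a number is the more likely outcome.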

Compound 4, half-maximal inhibitory concentration: 1830 nM
Compound 4: middle estimate off by 11-fold (1.04 log units), on the high side; measured number outside the range, below it.
By their numbers in this assay, from the lowest: compound 4; then compounds 1 and 2 (each within the scatter of the next). At a limit, above all of these: compound 3.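

Chloro in place of fluoro, para to a large group, gives a step beyond the scatter in this assay, an at least 10-fold lower number from compound 3 to compound 4 (1.03 log units; beyond the scatter), which shows that a single atom change at this position can move the number. For the compounds shown here, compound 4 also parts from the two methylphenyl compounds, with a 9.6-fold lower number from compound 2 to compound 4 (0.98 log units; beyond the scatter) and a 7.4-fold lower number from compound 1 to compound 4 (0.87 log units; beyond the scatter), whereas the earlier steps among compounds 1, 2 and 3 all stayed within the scatter. Compound 3 holds a limit and not a number, so its step has only a floor: the limit of > 20000 nM in this assay, at which 1 of the 4 values shown sits.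

The compounds shown leave open whether this drop belongs to chloro alone or would also come with bromo, methoxy or trifluoromethyl at the same place. Going by these compounds, whether an amine or a carboxylic acid there would keep it also remains open.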